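A few compounds are considered here, and "the series" means these few. Any claim that something is new, unique, unknown or untested is made for them only; others in the source may bear on it.

In a functional assay on MCF7 cells (Homo sapiens) for antiproliferative activity, read by luminescence, with a stated time of 24 h (on this read-out lower numbers stand for stronger inhibition and higher numbers for weaker inhibition), compound 3 `Cc1c(C)c2c(c(C)c1OC(=O)CCCCCCCNC(=O)OC(C)(C)C)CCC(C)(COc1ccc(/C=C3\SC(=O)NC3=O)cc1)O2` gives 13000 nM. Compound 1 `Cc1c(C)c2c(c(C)c1OC(=O)CCCC[C@@H]1SC[C@@H]3NC(=O)N[C@@H]31)CCC(C)(COc1ccc(CC3SC(=O)NC3=O)cc1)O2` gives 15900 nM, and these two values lie within the usual scatter of each other. Among the compounds with values here, they are the only two true numbers so far. Compound 2 `Cc1c(C)c2c(c(C)c1OC(=O)CCC(=O)O)CCC(C)(COc1ccc(/C=C3\SC(=O)NC3=O)cc1)O2` gives > 50000 nM, which is a limit of the assay and not a number.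

Compound 4 `Cc1c(C)c2c(c(C)c1OC(=O)CCCC[C@@H]1SC[C@@H]3NC(=O)N[C@@H]31)CCC(C)(COc1ccc(/C=C3\SC(=O)NC3=O)cc1)O2` changes compound 3 in one place (a group of 9 heavy atoms (5 carbon, 2 nitrogen, 1 oxygen, 1 sulfur; one five-membered non-aromatic ring with 1 hetero atom, one five-membered non-aromatic ring with 2 hetero atoms) in place of a group of 11 heavy atoms (8 carbon, 1 nitrogen, 2 oxygen; no ring), on a saturated chain carbon, four bonds along the chain from a carbonyl carbon). The 3-((tert-butoxycarbonyl)amino)propyl group leaves, and a group with one five-membered non-aromatic ring with 1 hetero atom and one five-membered non-aromatic ring with 2 hetero atoms enters, on a saturated chain carbon, four bonds along the chain from a carbonyl carbon.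

Within the data shown here, no two measured compounds differ in only one place, so no measured step shows what such a change does in this assay. With so little to go on, no shift beyond the scatter is expected in either direction. The estimated change is a 1.2-fold higher number from compound 3 to compound 4 (0.06 log units; within the scatter). Compound 4 is expected to give about 15000 nM, with an estimated range of 6000 nM to 40000 nM.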

Compound 4, half-maximal inhibitory concentration: 11200 nM
Compound 4: middle estimate off by 1.3-fold (0.13 log units), on the high side; low and high end bracket the measured number.
By their numbers in this assay, from the lowest: compounds 4, 3 and 1 (each within the scatter of the next). At a limit, above all of these: compound 2.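

In this assay, putting the two-ring group in place of the 3-((tert-butoxycarbonyl)amino)propyl group, on a saturated chain carbon four bonds along the chain from a carbonyl carbon, gives a 1.2-fold lower number from compound 3 to compound 4 (0.06 log units; within the scatter), so these two very different chain ends cannot be told apart here. The change on an aromatic carbon, where both groups have the same heavy-atom count, gives a 1.4-fold lower number from compound 1 to compound 4 (0.15 log units; within the scatter), so it cannot be told apart either. Only the replacement of the ring-free group of compound 2 by the larger two-ring group, on a saturated chain carbon two bonds along the chain from a carbonyl carbon, gives a step beyond the scatter, an at least 4.4-fold lower number from compound 2 to compound 4 (0.64 log units; beyond the scatter), and that step is read against a limit, not a number: the limit of > 50000 nM in this assay, at which 1 of the 4 values shown sits.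

From the compounds shown here alone, the true size of that step remains unknown. Going by these compounds, it also remains open whether a free amine or a carboxylic acid at the end of a longer chain would give a number like these or one at the limit.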